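Swapping ethyl for methylsulfanyl at the assay's limit

The source may hold more compounds than are shown below. What is called first, only, known or untested is meant among the compounds shown, and "the series" means these compounds.

Compound 1 (`CCc1ccc(-c2nc3ccccn3c2Sc2ccccc2)cc1`) gives > 100000 nM in a functional assay on MDA-MB-231 cells (Homo sapiens) for inhibition, read by MTT assay, with a stated time of 48 h (a lower number here means a stronger inhibitor, a higher number a weaker inhibitor), and that reading is a limit of the assay, not a number. Two related compounds do give numbers in this assay: compound 2 (`c1ccc(Sc2c(-c3cccc4ccccc34)nc3ccccn23)cc1`) gives 69300 nM and compound 3 (`c1ccc(Sc2c(-c3ccccc3)nc3ccc(-c4ccccc4)cn23)cc1`) gives 76700 nM and these two values lie within the usual scatter of each other.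

Compound 4 (`CSc1ccc(-c2nc3ccccn3c2Sc2ccccc2)cc1`) keeps the core of compound 1 and changes one group, with methylsulfanyl in place of ethyl on an aromatic carbon. This turns 4-ethylphenyl into 4-(methylsulfanyl)phenyl. Within the data shown here, no measured pair shows what this swap does, so the expectation leans on the relatives that gave numbers. Compound 2 at 69300 nM is still a weak inhibitor, so a large gain seems unlikely. The estimated at least 1.2-fold lower number from compound 1 to compound 4 (0.09 log units; that floor lies within the scatter) is small, toward a stronger inhibitor, and may not exceed the scatter. Compound 4 is expected near 80000 nM with a range from 30000 nM to 150000 nM and a fair chance of another limit reading.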

Compound 4, half-maximal inhibitory concentration: 23500 nM
The estimate for compound 4 lay 3.4-fold (0.53 log units) above the measured number, outside the stated range (below it).
By their numbers in this assay, from the lowest: compound 4; then compounds 2 and 3 (each within the scatter of the next). At a limit, above all of these: compound 1.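

Placing methylsulfanyl where ethyl stood, on the aromatic carbon para to a large group, gives an at least 4.2-fold lower number from compound 1 to compound 4 (0.62 log units; beyond the scatter) in this assay, the first sign that the group at this position can change the reading. Compound 1 gives > 100000 nM, which is a limit of the assay and not a number, so this step is only a floor and the true gap may be wider: the limit of > 100000 nM in this assay, at which 1 of the 4 values shown sits.

The change puts a sulfur into the group, but a single step cannot show what about the swap matters.

The compounds shown leave open whether the sulfur itself is needed, a question that a methoxy group or an amine at the same place could address. They also leave open whether a longer chain, such as propylsulfanyl, would move the number further in either direction.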